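Diaryl ether semicarbazone series: arylidene variation and cytotoxicity

The source may hold more compounds than are shown below. What is called first, only, known or untested is meant among the compounds shown, and "the series" means these compounds.

Measured compounds:
- compound 1, `COc1ccc(/C=N/NC(=O)Nc2ccc(Oc3ccnc(-c4nncn4CCN(C)C)c3)c(F)c2)c(OC)c1OC`: 1790 nM
- compound 2, `CN(C)CCn1cnnc1-c1cc(Oc2ccc(NC(=O)N/N=C/c3ccccc3O[N+](=O)[O-])cc2F)ccn1`: 1270 nM
- compound 3, `CN(C)CCn1cnnc1-c1cc(Oc2ccc(NC(=O)N/N=C/c3cccc(Br)c3)cc2F)ccn1`: 520 nM

In a functional assay on NCI-H460 cells (Homo sapiens) for cytotoxicity, read by MTT assay, with a stated time of 72 h (a higher number here means a weaker inhibitor, a lower number a stronger inhibitor), compound 3 holds the lowest number of the three: its steps to the others are a 3.4-fold lower number from compound 1 to compound 3 (0.54 log units; beyond the scatter) and a 2.4-fold lower number from compound 2 to compound 3 (0.39 log units; beyond the scatter), both beyond the scatter, so compound 3 is the strongest inhibitor of this set. Compounds 1 and 2 lie within the scatter of each other, as a 1.4-fold lower number from compound 1 to compound 2 (0.15 log units; within the scatter) shows.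

Compound 4, `COc1ccc(/C=N/NC(=O)Nc2ccc(Oc3ccnc(-c4nncn4CCN(C)C)c3)c(F)c2)cc1O`, is the next step: 3-hydroxy-4-methoxyphenyl in place of 3-bromophenyl on a carbon with a double bond to nitrogen. The step that bears on it most directly is a 3.4-fold lower number from compound 1 to compound 3 (0.54 log units; beyond the scatter), in which a methoxy-bearing phenyl gave way to the bromophenyl and the number fell modestly. Compound 4 largely runs that step backwards, keeping one methoxy and adding a hydroxyl, so a modest rise in this assay is expected, estimated as a 2.3-fold higher number from compound 3 to compound 4 (0.36 log units; beyond the scatter). Compound 4 is therefore expected at about 1200 nM, with a range from 500 nM to 3000 nM.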

Compound 4, half-maximal inhibitory concentration: 620 nM
Compound 4: middle estimate off by 1.9-fold (0.29 log units), on the high side; the measured number falls inside the stated range.
By their numbers in this assay, from the lowest: compounds 3 and 4 (each within the scatter of the next); then compounds 2 and 1 (each within the scatter of the next).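

In this assay the change to 3-hydroxy-4-methoxyphenyl gives a 1.2-fold higher number from compound 3 to compound 4 (0.08 log units; within the scatter) and so leaves the number where the 3-bromophenyl put it, which shows that this carbon with a double bond to nitrogen can carry a ring with no bromine and with oxygen substituents without losing the level of compound 3. The same group also stands apart from the two other oxygen-bearing rings, with a 2.0-fold lower number from compound 2 to compound 4 (0.31 log units; beyond the scatter) and with a 2.9-fold lower number from compound 1 to compound 4 (0.46 log units; beyond the scatter) as the steps, so oxygen substituents on this ring do not by themselves set the number. No measurement on hand accounts for these differences.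

In the compounds shown, the hydroxyl occurs only together with a methoxy in compound 4, so its separate contribution stays open. Also open, from the compounds shown here alone, is how an amine or a carboxylic acid on this phenyl ring would read in this assay.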